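The source may hold more compounds than are shown below. What is called first, only, known or untested is meant among the compounds shown, and "the series" means these compounds.

Compound 1 `COc1cc(OC)cc(N2CCN(C(=O)c3oc(C)nc3-c3cccc(F)c3)CC2)c1`: 98 nM
Compound 2 `Cc1nc(-c2ccccc2F)c(C(=O)N2CCN(c3cc(Cl)cc(Cl)c3)CC2)o1`: 204 nM

In a functional assay on A549 cells (Homo sapiens) for inhibition, read by MTT assay, with a stated time of 72 h (on this read-out higher numbers stand for weaker inhibition and lower numbers for stronger inhibition), compound 1 gives 98 nM, the lowest of the two numbers recorded, while compound 2 gives 204 nM, a higher number whose gap from compound 1 lies beyond the usual scatter. Within the data shown here, no single-point step between the two measured compounds is known, so nothing measured yet shows how a fluorine placed differently on the phenyl ring affects the read-out.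

Compound 3 `COc1cc(OC)cc(N2CCN(C(=O)c3oc(C)nc3-c3ccc(F)cc3)CC2)c1` differs from compound 1 in one place: 4-fluorophenyl in place of 3-fluorophenyl on an aromatic carbon. Among the measured compounds shown here, since no step between measured compounds speaks to this change, the expectation for compound 3 rests only on compound 1 and the small size of the change. The step of a 1.2-fold higher number from compound 1 to compound 3 (0.09 log units; within the scatter) is expected to be small, in no particular direction, and to stay within the scatter. Compound 3 is therefore estimated at 120 nM, with a range from 40 nM to 400 nM.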

Compound 3, half-maximal inhibitory concentration: 158 nM
Compound 3: middle estimate off by 1.3-fold (0.12 log units), on the low side; the measured number falls inside the stated range.
By their numbers in this assay, from the lowest: compounds 1, 3 and 2 (each within the scatter of the next, the first and the last beyond it).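

Among these compounds, this is the first comparison in which only one place differs. In this assay, 4-fluorophenyl in place of 3-fluorophenyl, on the aromatic carbon next to the ring nitrogen, comes with a 1.6-fold higher number from compound 1 to compound 3 (0.21 log units; within the scatter). The two fluorophenyl isomers therefore cannot be told apart on this read-out, and at this position the read-out tolerates this change of fluorine placement on the phenyl ring without a difference beyond the scatter. Nothing measured independently of this read-out bears on the result.

Still open, going by these compounds, is how a plain phenyl, a 4-chlorophenyl or a 4-methoxyphenyl would read at this same place, and so whether the fluorine matters at all. Also open, on these data alone, is how an ethyl in place of the methyl group on the same ring would read.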